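Chloro in Place of Trifluoromethyl: Metabolic Stability Compared

The source may report more compounds than this note shows. Statements on the series, on what has been measured and on what is new or still open speak of the compounds shown alone.

Of the compounds shown here, three sharing a core have been measured. In an ADME assay (Mus musculus) for metabolic stability (on this read-out lower numbers stand for a less stable compound and higher numbers for a more stable compound), compound 2 `Cc1nc(N[C@@H]2C[C@H]3CC[C@@H]2C3)c2cc(-c3cccc(C(F)(F)F)c3)ccc2n1` gives 41%, and compound 1 `Cc1nc(N[C@@H]2C[C@H]3CC[C@@H]2C3)c2cc(-c3cccc(Cl)c3)ccc2n1` gives 27%. The two differ in one place: chloro in place of trifluoromethyl on an aromatic carbon. That change made a number 14 percentage points lower from compound 2 to compound 1 (beyond the scatter). Compound 3 `FC(F)(F)c1ccc(-c2ccc3nc(Cl)nc(N[C@@H]4C[C@H]5CC[C@@H]4C5)c3c2)cc1` gives 95% in this assay, the highest of the three values; how its core differs from the core of compound 2 is not broken down here.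

Compound 4 `Clc1ccc(-c2ccc3nc(Cl)nc(N[C@@H]4C[C@H]5CC[C@@H]4C5)c3c2)cc1` has not yet been measured in this assay. It differs from compound 3 by the following: chloro in place of trifluoromethyl on an aromatic carbon. Compared with the change from compound 2 to compound 1, the leaving and entering groups are the same, but the place is not: in compound 1 the chloro sits meta to a large group, in compound 4 para to a large group. So the change is the same kind of change, not the same.

Beside the earlier step, the expected step is a number 17 percentage points lower from compound 3 to compound 4 (beyond the scatter), resting on the step seen from compound 2 to compound 1, a number 14 percentage points lower from compound 2 to compound 1 (beyond the scatter). For compound 4 in this assay the estimate is 78%.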

Compound 4, percent of the compound remaining: 40%
Compound 4: the middle estimate sits 38 percentage points above what was measured, outside the stated range (below it).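

In this assay, chloro in place of trifluoromethyl gives a lower number on both cores, so the direction of the change carries over, but its size does not, and the new step is a number 55 percentage points lower from compound 3 to compound 4 (beyond the scatter). Set side by side, the two steps differ by more than repeated measurements would normally explain: the same change on two cores in this assay, a number 14 percentage points lower (beyond the scatter) from compound 2 to compound 1 and a number 55 percentage points lower (beyond the scatter) from compound 3 to compound 4, 41 percentage points apart, beyond the scatter of two such steps. This shows that the size of the step on one core was a poor guide to its size on the other, but it does not show why, since the two pairs differ both in their cores and in where the group sits on the outer ring, and two pairs cannot separate these differences.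

The compounds shown leave open whether the step would stay this large if chloro and trifluoromethyl sat at the same place on both cores. They also leave open how a different group on that ring, such as a nitrile or an amine, would behave on each core.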